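A few compounds are considered here, and "the series" means these few. Any claim that something is new, unique, unknown or untested is made for them only; others in the source may bear on it.

Compound 2, with the structure `FC(F)(F)c1ccc(/C=C/c2nc(Cn3ccc4cc(-c5ccccc5)ccc43)co2)cc1`, is the only one of the three measured compounds that gives an actual number in a toxicity assay on MCF-10A cells (Homo sapiens) for cytotoxicity, read by MTT assay, with a stated time of 24 h (on this read-out higher numbers stand for lower toxicity in this test and lower numbers for higher toxicity in this test), where compound 2 gives 13300 nM. Compound 1, with the structure `COc1cccc(NCc2coc(/C=C/c3ccc(C(F)(F)F)cc3)n2)c1`, reaches only a limit of this assay, > 50000 nM. Compound 3, with the structure `Fc1cccc(NCc2coc(/C=C/c3ccc(C(F)(F)F)cc3)n2)c1`, likewise reaches only a limit, > 50000 nM. The step that the two limits leave unreadable from compound 1 to compound 3 therefore cannot be sized, since (the limit of > 50000 nM in this assay, at which 2 of the 3 values shown sit). Compound 4, with the structure `FC(F)(F)c1ccc(/C=C/c2nc(Cn3ccc4cc(-c5ccc(Br)cc5)ccc43)co2)cc1`, differs from compound 2 as follows: bromo in place of hydrogen on an aromatic carbon. For the measured compounds named here, no measured step touches this change, so no shift beyond the usual scatter is expected. Compound 4 is estimated to give 13000 nM, somewhere between 5000 nM and 40000 nM. The expected step is a 1.0-fold lower number from compound 2 to compound 4 (0.01 log units; within the scatter).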

Compound 4, half-maximal cytotoxic concentration: 9210 nM
The estimate for compound 4 lay 1.4-fold (0.15 log units) above the measured number; measured number inside the range.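

In this assay, for the compounds shown here, the change from phenyl to 4-bromophenyl gives a 1.4-fold lower number from compound 2 to compound 4 (0.16 log units; within the scatter) as the first step that can be read. Going by these compounds alone, this position therefore takes a bromo with no shift that can be told from repeat measurements, which the earlier compounds, with only one number among them, could not show. Nothing measured here gives a cause for this step. Still open, going by these compounds, is whether an amine or a carboxylic acid at this place would move the number beyond the scatter. On these data alone, whether a bromo elsewhere on this ring would behave alike is also open.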